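This account rests on a few compounds, and the source may have more. Where it says the series, first, only, none or still open, it means among the compounds named here.

For the measured compounds named here, compound 2 `CC1(C)OB(c2ccc(COc3ccc(CNC(=O)[C@@H]4CCC(=O)N4Cc4ccccc4)cc3)cc2)OC1(C)C` is the only compound here with a measured number: in an assay on HEK293 cells for inhibition of Ataxin-2 (Mus musculus), read by fluorescence and Amplex Red (a higher number here means a weaker inhibitor, a lower number a stronger inhibitor), compound 2 gives 50 nM. From the compounds shown here alone, compound 1 `COC(=O)c1ccc(COc2ccc(CNC(=O)[C@@H]3CCC(=O)N3Cc3ccccc3)cc2)cc1` reached only a limit in this assay, where compound 1 gives > 5000 nM, so its true value is unknown beyond (the limit of > 5000 nM in this assay, at which 1 of the 2 values shown sits). Going by the values given here, the one measured step, an at least 100-fold lower number from compound 1 to compound 2 (2.00 log units; beyond the scatter), follows a change on the same aromatic carbon. Compound 3 `O=C(NCc1ccc(OCc2ccccc2)cc1)[C@@H]1CCC(=O)N1Cc1ccccc1` differs from compound 2 by a hydrogen atom in place of a group of 9 heavy atoms (6 carbon, 1 boron, 2 oxygen; one five-membered non-aromatic ring with 3 hetero atoms), on an aromatic carbon. Taking away the boronate group is expected to weaken inhibition, a step of a 40-fold higher number from compound 2 to compound 3 (1.60 log units; beyond the scatter) in this assay. Compound 3 is therefore estimated at 2000 nM in this assay, with a likely range from 300 nM to 10000 nM.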

Compound 3, half-maximal inhibitory concentration: > 5000 nM
Compound 3: only a limit was reported; the forecaster's own chance of this, stated with the estimate: 40%; at least 2.5-fold (0.39 log units) between middle value and limit.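

With a hydrogen atom on this aromatic carbon, the result is an at least 100-fold higher number from compound 2 to compound 3 (2.00 log units; beyond the scatter), so the shared core alone does not give the inhibition seen with compound 2. Among the compounds shown, only the boronate group, and neither hydrogen nor methoxycarbonyl, goes with a measured number. The step between compound 1 and compound 3 cannot be read, since both values are limits and not numbers: the limit of > 5000 nM in this assay, at which 2 of the 3 values shown sit.

From the compounds shown here alone, it remains open whether a free boronic acid, a carboxylic acid or an amine on this carbon would keep any of the inhibition.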